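This account rests on a few compounds, and the source may have more. Where it says the series, first, only, none or still open, it means among the compounds named here.

Going by the values given here, compound 1 `CC(C)(C)OC(=O)N1CCC[C@H]1C(=O)N1CCC(NS(=O)(=O)c2cc(S(=O)(=O)c3ccccc3)ccc2C(F)(F)F)CC1` gives 60 nM in a functional assay on U2OS cells for antagonist activity at proto-oncogene Wnt-3 (Homo sapiens), read by a luciferase reporter, with a stated time of 18 h (a lower number here means that less compound is needed, a higher number that more compound is needed for the effect), the lower of the two numbers measured so far. Its partner, compound 2 `CC(C)(C)C(=O)N1CCC[C@H]1C(=O)N1CCC(NS(=O)(=O)c2cc(S(=O)(=O)c3ccccc3)ccc2C(F)(F)F)CC1`, gives 270 nM in this assay, a step of a 4.5-fold higher number from compound 1 to compound 2 (0.65 log units; beyond the scatter) after tert-butyl in place of tert-butoxy on a carbonyl carbon. The new compound 3 `O=C([C@@H]1CCCN1C(=O)Nc1ccccc1)N1CCC(NS(=O)(=O)c2cc(S(=O)(=O)c3ccccc3)ccc2C(F)(F)F)CC1` carries the change (anilino in place of tert-butoxy on a carbonyl carbon). Among the compounds with values here, only the step from compound 1 to compound 2 bears on this, and only loosely: it shows that replacing the tert-butoxy group at this carbonyl carbon with another group cost a modest amount, yet anilino is not tert-butyl, so the size and even the direction remain open. A modest rise, comparable to the one seen, is the more likely outcome, with a fair chance of no change beyond the scatter. Compound 3 is therefore expected to give about 150 nM in this assay, within 40 nM to 600 nM, an estimated step of a 2.5-fold higher number from compound 1 to compound 3 (0.40 log units; beyond the scatter).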

Compound 3, half-maximal effective concentration: 310 nM
For compound 3 the middle estimate is 2.1-fold (0.32 log units) below the measured one; measured number inside the range.
By their numbers in this assay, from the lowest: compound 1; then compounds 2 and 3 (each within the scatter of the next).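

In this assay, the step of a 5.2-fold higher number from compound 1 to compound 3 (0.71 log units; beyond the scatter) follows the swap of tert-butoxy for anilino, so a second, quite different replacement on this carbonyl carbon also gives a higher number than tert-butoxy. Between the two replacements, the step of a 1.1-fold higher number from compound 2 to compound 3 (0.06 log units; within the scatter) follows anilino in place of tert-butyl, so the six-membered aromatic ring and hydrogen-bond donor that anilino brings leave compound 3 level with compound 2, and among these three compounds only tert-butoxy stands apart. Nothing measured here gives a reason for this.

As far as these compounds go, it remains open whether another group joined through oxygen, such as methoxy or benzyloxy, would match compound 1. A nitrogen-linked group without an aromatic ring, such as cyclohexylamino or dimethylamino, could show whether anilino's result extends beyond anilino itself.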